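Methyl for fluoro on a well-tolerated scaffold

A few compounds are considered here, and "the series" means these few. Any claim that something is new, unique, unknown or untested is made for them only; others in the source may bear on it.

Compound 1, `Cc1ccc(-c2c3c(nc(C)c2C(OC(C)(C)C)C(=O)O)CCN(c2cccc(-c4ccccc4)c2)C3)cc1`: in an ADME assay on MT2 cells (Homo sapiens) for cytotoxicity, read by XTT assay, with a stated time of 4 days (a lower number here means that less compound is tolerated, a higher number that more compound is tolerated), compound 1 gives > 40000 nM, a limit of the assay rather than a number.
Compound 2, `COC(=O)N1CCc2nc(C)c(C(OC(C)(C)C)C(=O)O)c(-c3ccc(C)cc3)c2C1`: in this assay compound 2 gives > 40000 nM, also a limit.
Compound 3, `Cc1nc2c(c(-c3cc(F)c4c(c3C)CCCO4)c1[C@H](OC(C)(C)C)C(=O)O)CN(CCCc1cccc(F)c1)CC2`: in this assay compound 3 gives > 40000 nM, again a limit.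

Of the compounds shown here, three built on a shared core have been tested so far, and none of them yields a number: every result is the limit of > 40000 nM in this assay, at which 3 of the 3 values shown sit. Within the data shown here, the single change that connects two of them, a step that the two limits leave unreadable from compound 1 to compound 2, therefore cannot be read for size or direction. Compound 3 stands exactly where the other two stand, at the limit, and nothing separates it from them.

The next compound, compound 4, `Cc1cccc(CCCN2CCc3nc(C)c([C@H](OC(C)(C)C)C(=O)O)c(-c4cc(F)c5c(c4C)CCCO5)c3C2)c1`, differs from compound 3 in one place: methyl in place of fluoro on an aromatic carbon. Among the measured compounds shown here, no measured step bears on this change, since the only step available is unreadable. The reasonable expectation is that compound 4 stays where compound 3 stands, because compound 3 gives > 40000 nM and every companion shares that limit. The step that the limit leaves unreadable from compound 3 to compound 4 is therefore expected to be none beyond the scatter. For compound 4 the expected value is 60000 nM, with a range from 30000 nM to 200000 nM.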

Compound 4, half-maximal cytotoxic concentration: > 40000 nM
Compound 4: only a limit was reported; the forecaster's own chance of this, stated with the estimate: 85%; the middle value does not contradict the limit.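

No new step can be read from compound 3 to compound 4: both results are limits rather than numbers, so methyl in place of fluoro has no readable size or direction, and all the compounds share one result: the limit of > 40000 nM in this assay, at which 4 of the 4 values shown sit.

The compounds shown leave open at what concentration any of them would harm the cells in this assay, and whether any change on the shared core would set one apart from another.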